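The source may hold more compounds than are shown below. What is called first, only, known or untested is meant among the compounds shown, and "the series" means these compounds.

Compound 1, `NS(=O)(=O)c1ccc(NC(=S)Nc2ccc3ncnc(Nc4cccc(C(F)(F)F)c4)c3c2)cc1`: 7590 nM in a functional assay on NCI-H1975 cells (Homo sapiens) for antiproliferative activity, read by MTT assay, with a stated time of 72 h; a lower number here means a stronger inhibitor, a higher number a weaker inhibitor
Compound 2, `NS(=O)(=O)c1ccc(NC(=S)Nc2ccc3ncnc(Nc4ccc(Cl)c(C(F)(F)F)c4)c3c2)cc1`: 11800 nM in this assay

Compound 2 and compound 1 are separated only by the step of a 1.6-fold higher number from compound 1 to compound 2 (0.19 log units; within the scatter), a gap within the scatter, so on the numbers shown the two compounds stand level and compound 2 cannot be set apart from compound 1.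

Compound 3, `NS(=O)(=O)c1ccc(NC(=S)Nc2ccc3ncnc(Nc4cccc(Br)c4)c3c2)cc1`, differs from compound 2 by 3-bromophenyl in place of 4-chloro-3-(trifluoromethyl)phenyl on a nitrogen on an aromatic ring. Going by the values given here, the single measured step, a 1.6-fold higher number from compound 1 to compound 2 (0.19 log units; within the scatter), concerns only a chloro added to the same ring and stays within the scatter; no measured step involves the trifluoromethyl group or a bromo, so the data give no pointer on the new group. In this assay the expectation is therefore no step beyond the scatter, with compound 3 expected close to the numbers of compound 1 and compound 2. Compound 3 is estimated at 9000 nM, within 3000 nM to 27000 nM. That estimate means an expected step of a 1.3-fold lower number from compound 2 to compound 3 (0.12 log units; within the scatter).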

Compound 3, half-maximal inhibitory concentration: 11000 nM
The estimate for compound 3 lay 1.2-fold (0.09 log units) below the measured number; the measured number falls inside the stated range.
By their numbers in this assay, from the lowest: compounds 1, 3 and 2 (each within the scatter of the next).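

With 3-bromophenyl in place of 4-chloro-3-(trifluoromethyl)phenyl on the nitrogen, this assay gives a 1.1-fold lower number from compound 2 to compound 3 (0.03 log units; within the scatter), while bromo in place of trifluoromethyl on an aromatic carbon gives a 1.4-fold higher number from compound 1 to compound 3 (0.16 log units; within the scatter). Going by these compounds alone, these steps show for the first time that exchanging the trifluoromethyl group, alone or together with the chloro, leaves the number within the scatter, so compound 1, compound 2 and compound 3 stand level. No evidence is available that bears on this result.

As far as these compounds go, the three compounds carry only trifluoromethyl, chloro and bromo on this ring, so it remains open whether an amine, a carboxylic acid or a methoxy group there would move the number beyond the scatter. From the compounds shown here alone, the rest of the molecule is the same in all three, so what its parts contribute also stays open.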